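From methoxy to methylsulfanyl on compound 1

The compounds below may be only part of what the source reports. "The series", "measured", "known", "first", "only" and "open" are said of these compounds alone.

In a functional assay on MDA-MB-435 cells (Homo sapiens) for antiproliferative activity, read by sulforhodamine B assay (on this read-out lower numbers stand for stronger inhibition and higher numbers for weaker inhibition), compound 1 (`COc1ccc(N(C)c2nc(C)nc3ccccc23)cc1`) gives 1.7 nM and compound 2 (`COc1ccc2c(c1)CCCN2c1nc(C)nc2ccccc12`) gives 1.1 nM as its reading. These two values lie within the usual scatter of each other, so compound 1 does not stand apart from compound 2. Compound 3 (`CSc1ccc(N(C)c2nc(C)nc3ccccc23)cc1`) has methylsulfanyl in place of methoxy on an aromatic carbon, para to a large group. Among the measured compounds shown here, no measured pair shows this swap, so the forecast is loose. A modest move toward weaker inhibition, just beyond the scatter, is expected (a 2.9-fold higher number from compound 1 to compound 3 (0.47 log units; beyond the scatter)). The estimate for compound 3 is an expected 5 nM (range 1.5 nM to 25 nM).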

Compound 3, half-maximal inhibitory concentration: 1.2 nM
Beside the measured number, compound 3's estimate is 4.2-fold (0.62 log units) above it; the whole stated range lies above it.
By their numbers in this assay, from the lowest: compounds 2, 3 and 1 (each within the scatter of the next).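

In this assay methylsulfanyl in place of methoxy, on an aromatic carbon para to a large group, gives a 1.4-fold lower number from compound 1 to compound 3 (0.15 log units; within the scatter) and so no real change. Among the compounds shown here, in this one pair, then, the position accepts sulfur in place of oxygen with the reading held, which the earlier compounds could not show. Nothing at hand accounts for the two groups reading alike.

On these data alone, whether a hydroxyl, an amine or a longer chain such as ethoxy would hold the reading at this position stays open. So does whether the same swap on compound 2 would behave in the same way.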